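Series notes: carboxy to longer chain on the shared core

The source may report more compounds than this note shows. Statements on the series, on what has been measured and on what is new or still open speak of the compounds shown alone.

Among the measured compounds shown here, compound 3 `O=C(O)CCn1nc(-c2ccccc2)ccc1=O` stands lowest of the three measured members in a functional assay on the whole organism (stomach) for inhibition, with Rattus norvegicus as the target, at a dose of 100 mg/kg by the intraduodenal route (on this read-out higher numbers stand for more inhibition at the one dose given (going by the name of the read-out) and lower numbers for less inhibition), with compound 3 giving 26.1%. Compound 1 `C/N=C(\S)CCn1nc(-c2ccccc2)ccc1=O` gives 68.2% and compound 2 `N=C(S)CCn1nc(-c2ccccc2)ccc1=O` gives 53.7%; both steps to compound 3 are beyond the scatter, a number 42.1 percentage points lower from compound 1 to compound 3 (beyond the scatter) and a number 27.6 percentage points lower from compound 2 to compound 3 (beyond the scatter). Compound 4 `N=C(S)CCCCn1nc(-c2ccccc2)ccc1=O` is not yet measured. The change is a group of 5 heavy atoms (3 carbon, 1 nitrogen, 1 sulfur; no ring) in place of a group of 3 heavy atoms (1 carbon, 2 oxygen; no ring), on a saturated chain carbon, two bonds along the chain from an aromatic nitrogen. For the measured compounds named here, the steps that bear on it are those in which carboxy replaced the nitrogen- and sulfur-containing groups: a number 27.6 percentage points lower from compound 2 to compound 3 (beyond the scatter) and a number 42.1 percentage points lower from compound 1 to compound 3 (beyond the scatter). From the compounds shown here alone, compound 4 therefore removes carboxy, so the direction expected in this assay is upward, toward the region of compound 2, though the entering group carries a longer chain than anything measured and its effect on the number is unknown. Compound 4 is expected to give about 50%, within 30% to 70%, an expected step of a number 23.9 percentage points higher from compound 3 to compound 4 (beyond the scatter).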

Compound 4, a percentage reported as inhibition, in the whole organism at one dose (the size of the read-out at that dose, not a potency): 33.8%
Compound 4: the middle estimate sits 16.2 percentage points above what was measured; measured number inside the range.
By their numbers in this assay, from the lowest: compounds 3 and 4 (each within the scatter of the next); then compound 2; then compound 1.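

In this assay, losing carboxy at this position does not by itself raise the number: the step is a number 7.7 percentage points higher from compound 3 to compound 4 (within the scatter) and leaves compound 3 and compound 4 unresolved. The same end group on a shorter chain reads clearly differently, with a number 19.9 percentage points lower from compound 2 to compound 4 (beyond the scatter) as the step, so at this place on the saturated chain the end group cannot be judged apart from the chain that carries it; the gap to the best member is wider, with a number 34.4 percentage points lower from compound 1 to compound 4 (beyond the scatter) as the step. No measurement at hand accounts for these differences.

Open, from the compounds shown here alone, is the shape of the chain-length dependence, since a chain of intermediate length would show whether the number falls gradually or abruptly. Also open, going by these compounds, is how a carboxylic acid or the end group of compound 1 would read on the longer chain of compound 4.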